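Ester Aryl Exchange on the Shared Core of Compound 1

The source may hold more compounds than are shown below. What is called first, only, known or untested is meant among the compounds shown, and "the series" means these compounds.

Compound 1 `COc1ccc(C(=O)Oc2cc3c(cc2C)[C@@H](C(C)C)CC=C3C)cc1` carries a 4-methoxyphenyl ester. In a functional assay on HCT-15 cells (Homo sapiens) for antiproliferative activity, read by sulforhodamine B assay, with a stated time of 48 h, tested at 50 uM (on this read-out higher numbers stand for more inhibition at the one concentration tested (going by the name of the read-out) and lower numbers for less inhibition), compound 1 gives 30.8%, the lowest of the three numbers measured here. Compound 2 `COc1ccc(C(=O)Oc2cc3c(C)ccc(C(C)C)c3cc2C)cc1`, built on a different core, gives 84% in this assay, and compound 3 `Cc1cc2c(C(C)C)ccc(C)c2cc1OC(=O)c1ccc(C(F)(F)F)cc1` gives 55.6%. Going by the values given here, the one step between measured compounds that differ in a single place, a number 28.4 percentage points lower from compound 2 to compound 3 (beyond the scatter), puts trifluoromethyl in place of methoxy on an aromatic carbon of the ester ring.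

Compound 4 `CC1=CC[C@H](C(C)C)c2cc(C)c(OC(=O)c3cccc([N+](=O)[O-])c3)cc21` has not yet been measured. It differs from compound 1 by 3-nitrophenyl in place of 4-methoxyphenyl on a carbonyl carbon. Among the compounds with values here, no measured pair shows exactly this change. Within the data shown here, the only step that bears on it is the one from compound 2 to compound 3, where methoxy likewise leaves the ester ring and another group enters, with the drop noted above; that step stands on a different core and on a different entering group, so it serves only as a hint of direction. The step of a number 8.8 percentage points lower from compound 1 to compound 4 (within the scatter) is therefore expected to be a modest fall, one that may or may not clear the scatter. Compound 4 is estimated at 22%, with a range from 5% to 42%.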

Compound 4, a percentage reported as inhibition, at one concentration (the size of the read-out at that concentration, not a potency): 45.9%
Beside the measured number, compound 4's estimate is 23.9 percentage points below it; the whole stated range lies below it.
By their numbers in this assay, from the lowest: compound 1; then compounds 4 and 3 (each within the scatter of the next); then compound 2.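

On the shared core of compound 1, the ester aryl group is now seen to change the result directly: in this assay, exchanging 4-methoxyphenyl for 3-nitrophenyl on the carbonyl carbon gives a number 15.1 percentage points higher from compound 1 to compound 4 (beyond the scatter). The earlier compounds shown here showed only a number 28.4 percentage points lower from compound 2 to compound 3 (beyond the scatter), on a different core and with trifluoromethyl as the entering group, so the two steps that remove methoxy from the ester ring run in opposite directions, and the loss of methoxy does not by itself set the direction across these compounds. The data shown offer no measured basis for explaining the rise on the core of compound 1.

With a single exchange on this core, the compounds shown leave open whether the rise follows from the departure of 4-methoxyphenyl, the arrival of 3-nitrophenyl, or the particular pairing of the two. They also leave open how this core would respond to an ester ring bearing an amine or a carboxylic acid, and whether 3-nitrophenyl would give a step of the same direction on the core of compound 2.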